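Nitrooxy for bromo on the acyl side chain

The source may report more compounds than this note shows. Statements on the series, on what has been measured and on what is new or still open speak of the compounds shown alone.

Compound 1 `O=C(CBr)Nc1ccc(C(=O)/C=C/c2ccco2)cc1` and compound 2 `O=C(CO[N+](=O)[O-])Nc1ccc(C(=O)/C=C/c2ccco2)cc1` share one core; compound 3 `CC(Br)C(=O)Nc1ccc(C(=O)/C=C/c2ccc(Cl)cc2)cc1` and compound 4 `CC(O[N+](=O)[O-])C(=O)Nc1ccc(C(=O)/C=C/c2ccc(Cl)cc2)cc1` share another. The difference between the two cores is not broken down here. In a functional assay on the whole organism (strain albino) for inhibition, with Rattus norvegicus as the target, read by paw edema, with stated times of 30 min and 1 h, at a dose of 100 mg/kg by the oral route (a higher number here means more inhibition at the dose given (going by the name of the read-out), a lower number less inhibition), compound 1 gives 30% and compound 2 gives 34%; the step of a number 4 percentage points higher from compound 1 to compound 2 (within the scatter) follows the change (nitrooxy in place of bromo on a saturated chain carbon bound to a carbonyl carbon). In this assay compound 3 gives 39%, a number that stands within the scatter of both compound 1 and compound 2, so no order among the three is claimed.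

Compound 4 is not yet measured. It is related to compound 3 by nitrooxy in place of bromo on a saturated chain carbon bound to a carbonyl carbon and a saturated chain carbon. This is the same kind of change as that from compound 1 to compound 2, but the place is not the same word for word: in the first pair the carbon carrying the group is bound to a carbonyl carbon, in the second it is bound to a carbonyl carbon and a saturated chain carbon. Going by the values given here, only one measured instance of the change exists, and that one lies within the scatter, so the expectation rests on a single step. Compound 4 is expected to show a step of about a number 4 percentage points higher from compound 3 to compound 4 (within the scatter). This expectation rests on a number 4 percentage points higher from compound 1 to compound 2 (within the scatter) and on the reading of compound 3, 39%. In this assay compound 4 is estimated at 43%, with a likely range from 30% to 56%.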

Compound 4, a percentage reported as inhibition, in the whole organism at one dose (the size of the read-out at that dose, not a potency): 45%
The estimate for compound 4 lay 2 percentage points below the measured number; measured number inside the range.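

In this assay, the new step is a number 6 percentage points higher from compound 3 to compound 4 (within the scatter), with nitrooxy in place of bromo on a saturated chain carbon bound to a carbonyl carbon and a saturated chain carbon. Set beside the earlier step, the change carries from one core to the other with no difference that can be read: the same change on two cores in this assay, a number 4 percentage points higher (within the scatter) from compound 1 to compound 2 and a number 6 percentage points higher (within the scatter) from compound 3 to compound 4, 2 percentage points apart, within the scatter of two such steps. Going by these compounds alone, this agreement does not show that nitrooxy gives more inhibition than bromo on either core: each step on its own lies within the scatter, and the two pairs offer only two small steps at a single oral dose, so they fit a small gain and no gain alike.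

The compounds shown leave open whether another group on the same saturated chain carbon, such as an amine or a carboxylic acid, would read differently from bromo and nitrooxy in this assay. They also leave open whether nitrooxy on a longer chain would give a step of similar size, and whether the match between the two steps would hold on any core beyond these two.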